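Methoxy for fluoro on two cores: Vero cytotoxicity notes

A few compounds are considered here, and "the series" means these few. Any claim that something is new, unique, unknown or untested is made for them only; others in the source may bear on it.

Measured compounds:
compound 1 `Fc1ccc(-c2nn3c(NC4CC4)cc(Cl)cc3c2-c2ccnc(NC3CCCC3)n2)cc1`: > 40000 nM
compound 2 `COc1ccc(-c2nn3c(NC4CC4)cc(Cl)cc3c2-c2ccnc(NC3CCCC3)n2)cc1`: > 40000 nM
compound 3 `CSc1cc(NC2CCCC2)cc2c(-c3ccnc(NC4CCCC4)n3)c(-c3ccc(F)cc3)nn12`: > 40000 nM

In an ADME assay on Vero cells (Chlorocebus sabaeus) for cytotoxicity (on this read-out lower numbers stand for higher toxicity in this test and higher numbers for lower toxicity in this test), compound 1 gives > 40000 nM, which is a limit of the assay and not a number. In this assay compound 2 gives > 40000 nM, again a limit. In this assay compound 3 gives > 40000 nM, also a limit. Compound 2 differs from compound 1 by methoxy in place of fluoro on an aromatic carbon, and the step that the two limits leave unreadable from compound 1 to compound 2 cannot be read in size since both values are limits. The evidence on this point is the limit of > 40000 nM in this assay, at which 3 of the 3 values shown sit.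

Compound 3 is built on a different core than compound 1; the difference between the two cores is not broken down here. Compound 4 `COc1ccc(-c2nn3c(SC)cc(NC4CCCC4)cc3c2-c2ccnc(NC3CCCC3)n2)cc1` is not yet measured and differs from compound 3 by methoxy in place of fluoro on an aromatic carbon, the same change as from compound 1 to compound 2, at a place described in the same words.

For compound 4 an essentially flat step is expected, a step that the limit leaves unreadable from compound 3 to compound 4, resting on compound 3 giving > 40000 nM and on the fact that the limit of > 40000 nM in this assay, at which 3 of the 3 values shown sit, holds for all three measured values. Compound 4 is therefore estimated at 60000 nM, with the expected range from 30000 nM to 150000 nM, and most likely the assay will again report only a limit.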

Compound 4, half-maximal cytotoxic concentration: > 40000 nM
Compound 4 was reported as a limit; the forecaster's own chance of this, stated with the estimate: 85%; the middle value is on the limit's open side.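

In this assay compound 4 gives > 40000 nM which is a limit and not a number. No new step can be read from compound 3 to compound 4 because both values are limits: the limit of > 40000 nM in this assay, at which 4 of the 4 values shown sit.

The compounds shown leave open whether methoxy in place of fluoro changes cytotoxicity on either core, and at what concentration any of the four compounds would become toxic to these cells.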